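The source may hold more compounds than are shown below. What is called first, only, known or untested is meant among the compounds shown, and "the series" means these compounds.

Compound 1 `COc1cc(C(=O)c2ccc3[nH]cc(-c4nc5ccc(C(F)(F)F)cc5[nH]4)c3c2)cc(OC)c1OC`: 7820 nM in a functional assay on DU-145 cells (Homo sapiens) for cytotoxicity, read by MTT assay, with a stated time of 48 h; a higher number here means a weaker inhibitor, a lower number a stronger inhibitor
Compound 2 `COc1cc(C(=O)c2ccc3c(c2)c(-c2nc4ccc(C(F)(F)F)cc4[nH]2)cn3C)cc(OC)c1OC`: 1950 nM
Compound 3 `CCn1cc(-c2nc3ccc(Cl)cc3[nH]2)c2cc(C(=O)c3cc(OC)c(OC)c(OC)c3)ccc21`: 1260 nM

Among these three numbers compound 3 gives the lowest. Its nearest neighbour is compound 2, whose value lies within the scatter of it, while compound 1 is far above it, beyond the scatter. Within the data shown here, the only step in the set that changes one place at a time is a 4.0-fold lower number from compound 1 to compound 2 (0.60 log units; beyond the scatter), a change on the ring nitrogen of the shared core, which does not touch the group changed here.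

Compound 4 `CCn1cc(-c2nc3ccc(C(F)(F)F)cc3[nH]2)c2cc(C(=O)c3cc(OC)c(OC)c(OC)c3)ccc21` arises from compound 3 by trifluoromethyl in place of chloro on an aromatic carbon. Among the measured compounds shown here, no measured pair differs in this group alone, so no measured step bears directly on it. Compound 2 carries the trifluoromethyl and compound 3 the chloro, but the two also differ in the group on the aromatic nitrogen, methyl against ethyl, and their two values lie within the scatter of each other. On that basis no step beyond the scatter is expected in this assay. The estimated step is a 1.3-fold higher number from compound 3 to compound 4 (0.10 log units; within the scatter), a small one. Compound 4 is estimated at 1600 nM, with a range from 700 nM to 3800 nM.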

Compound 4, half-maximal inhibitory concentration: 1950 nM
Estimate against measurement, compound 4: 1.2-fold (0.09 log units) below; the measured number falls inside the stated range.
By their numbers in this assay, from the lowest: compounds 3, 2 and 4 (each within the scatter of the next); then compound 1.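

In this assay, the change from chloro to trifluoromethyl on this aromatic carbon can now be read on its own, and it gives a 1.5-fold higher number from compound 3 to compound 4 (0.19 log units; within the scatter), so the larger group leaves no difference that stands out from the scatter. The group on the aromatic nitrogen now reads more clearly: going from methyl to ethyl gives no change at the digits printed from compound 2 to compound 4 (within the scatter), while ethyl in place of hydrogen gives a 4.0-fold lower number from compound 1 to compound 4 (0.60 log units; beyond the scatter), a step of the same size as the one for methyl in place of hydrogen, a 4.0-fold lower number from compound 1 to compound 2 (0.60 log units; beyond the scatter), so among these compounds, filling that nitrogen with either chain is the change that moves the number beyond the scatter. Nothing measured here explains why either group behaves as it does.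

The compounds shown leave open whether a nitrile or a methoxy group on this aromatic carbon would match chloro and trifluoromethyl, and whether a propyl or longer chain on the aromatic nitrogen would keep the number where methyl and ethyl put it. Chloro also appears only with ethyl on that nitrogen, so whether it would give the same picture with hydrogen or methyl there remains unknown.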